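The compounds below may be only part of what the source reports. "The series", "measured", "known", "first", "only" and "open" are said of these compounds alone.

Measured in an ADME assay on the whole organism (strain Sprague-Dawley) with Rattus norvegicus as the target, at a dose of 1 mg/kg by the intravenous route; a lower number here means that the compound disappears faster, a higher number that the compound lasts longer:
- compound 1 `COc1cc2nccc(Oc3ccc(NC(=O)c4c(-c5ccccc5)n(C)n(-c5ccccc5)c4=O)nc3)c2cc1OC`: 10.4 h
- compound 2 `CNc1ncc2ccc(Oc3cc(C(=O)c4c(-c5ccccc5)n(C)n(-c5ccccc5)c4=O)ccc3N)cc2n1`: 0.5 h
- compound 3 `Cc1ncc2ccc(Oc3c(C)ccc(C(=O)c4c(-c5ccccc5)n(C)n(-c5ccccc5)c4=O)c3N)cc2n1`: 1.4 h

Among these three, compound 3 holds the middle place at 1.4 h, with compound 2 lower and compound 1 higher, both gaps beyond the scatter.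

Compound 4 `Cc1ccc(C(=O)c2c(-c3ccccc3)n(C)n(-c3ccccc3)c2=O)c(N)c1-c1ccc2nc(C(F)F)sc2c1` is not yet measured. It differs from compound 3 on an aromatic carbon, ortho to a methyl group and ortho to an amino group: 2-(difluoromethyl)-1,3-benzothiazol-6-yl in place of (2-methylquinazolin-7-yl)oxy on an aromatic carbon.

Among the measured compounds shown here, no two measured compounds differ in just one place, so nothing measured shows directly what this swap does. With so little to go on, only a small upward step, not beyond the scatter, is expected in this assay. The estimated change is a 1.3-fold higher number from compound 3 to compound 4 (0.11 log units; within the scatter). Compound 4 is expected at 1.8 h, within a range of 0.6 h to 5.5 h.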

Compound 4, mean residence time: 5.3 h
For compound 4 the middle estimate is 2.9-fold (0.47 log units) below the measured one; the measured number falls inside the stated range.
By their numbers in this assay, from the lowest: compound 2; then compound 3; then compounds 4 and 1 (each within the scatter of the next).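

On the aromatic carbon ortho to a methyl group and ortho to an amino group, 2-(difluoromethyl)-1,3-benzothiazol-6-yl in place of (2-methylquinazolin-7-yl)oxy gives a 3.8-fold higher number from compound 3 to compound 4 (0.58 log units; beyond the scatter) in this assay. Among the compounds shown here, this is the first direct sign that the group at this position can change how long these compounds last. No available data explain the step.

As far as these compounds go, the swap changes the ring system and drops the oxygen link together, so their separate contributions remain unknown. A 2-methyl-1,3-benzothiazol-6-yl group, or the difluoromethyl benzothiazole attached through oxygen, could help separate them.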